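Methoxy on the anilino ring of compound 3

A few compounds are considered here, and "the series" means these few. Any claim that something is new, unique, unknown or untested is made for them only; others in the source may bear on it.

Measured so far in a functional assay on MKN-74 cells (Homo sapiens) for antiproliferative activity, with a stated time of 24 h; a higher number here means a weaker inhibitor, a lower number a stronger inhibitor:
compound 1, `N#Cc1ccccc1CN1CCc2c(sc(NC(=O)c3ccccc3Cl)c2C(N)=O)C1`: 9500 nM
compound 2, `NC(=O)c1c(NC(=O)c2ccccc2Cl)sc2c1CCN(Cc1ccc([N+](=O)[O-])cc1)C2`: 31500 nM
compound 3, `NC(=O)c1c(NC(=O)c2ccccc2Cl)sc2c1CCN(C(=S)Nc1ccccc1)C2`: 15600 nM

Compound 3 stands second highest of the three numbers. The step of a 1.6-fold higher number from compound 1 to compound 3 (0.22 log units; within the scatter) is within the scatter, whereas the step of a 2.0-fold lower number from compound 2 to compound 3 (0.31 log units; beyond the scatter) is modest and beyond it. The two steps that change the group on the amine nitrogen in the ring, a 3.3-fold higher number from compound 1 to compound 2 (0.52 log units; beyond the scatter) and a 2.0-fold lower number from compound 2 to compound 3 (0.31 log units; beyond the scatter), both swap that entire group and still move the number only modestly.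

Compound 4 is `COc1ccccc1NC(=S)N1CCc2c(sc(NC(=O)c3ccccc3Cl)c2C(N)=O)C1`. It differs from compound 3 by methoxy in place of hydrogen on an aromatic carbon. Among the measured compounds shown here, no measured pair adds a single substituent to an otherwise unchanged aromatic ring; the nearest comparisons, a 3.3-fold higher number from compound 1 to compound 2 (0.52 log units; beyond the scatter) and a 2.0-fold lower number from compound 2 to compound 3 (0.31 log units; beyond the scatter), involve larger exchanges and yet stay modest. A smaller change is therefore expected to give a step within the scatter or at most of modest size, with no direction fixed by the data. The number for compound 4 in this assay is estimated at 14000 nM, between 6000 nM and 35000 nM, which is expected to mean a step of a 1.1-fold lower number from compound 3 to compound 4 (0.05 log units; within the scatter).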

Compound 4, half-maximal inhibitory concentration: 35200 nM
The estimate for compound 4 lay 2.5-fold (0.40 log units) below the measured number; the whole stated range lies below it.
By their numbers in this assay, from the lowest: compounds 1 and 3 (each within the scatter of the next); then compounds 2 and 4 (each within the scatter of the next).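

In this assay methoxy in place of hydrogen on the anilino ring, ortho to a large group, gives a 2.3-fold higher number from compound 3 to compound 4 (0.35 log units; beyond the scatter) and shows that even this single substituent can move the number beyond the scatter, to a modest degree. The new compound also changes how the group on the ring amine nitrogen compares across the series: a 1.1-fold higher number from compound 2 to compound 4 (0.05 log units; within the scatter) is a step within the scatter, while a 3.7-fold higher number from compound 1 to compound 4 (0.57 log units; beyond the scatter) is modest and beyond it. No supporting measurement accounts for the higher number with methoxy.

Going by these compounds, it remains open whether this step is specific to methoxy or would also follow from hydroxy, chlorine or ethoxy on the same carbon. Also open, on these data alone, is whether methoxy on another carbon of that ring would give a step of similar size and direction.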